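Replacing a tert-butyl group with ethoxy on a shared core

The compounds below may be only part of what the source reports. "The series", "measured", "known", "first", "only" and "open" are said of these compounds alone.

Of the compounds shown here, three built on one shared core have been tested in an assay on cells for inhibition of Palmitoleoyl-protein carboxylesterase NOTUM variant C330S (Homo sapiens), read by fluorescence, with a stated time of 40 min; on this read-out higher numbers stand for weaker inhibition and lower numbers for stronger inhibition. Compound 1 `Cc1cccc(-n2c(C)cc(C(=O)O)c2C)c1` gives 1500 nM. Compound 2 `Cc1cc(C(=O)O)c(C)n1-c1cccc(C(F)(F)F)c1` gives 1500 nM in this assay, and no change at the digits printed from compound 1 to compound 2 (within the scatter). Compound 3 `Cc1cc(C(=O)O)c(C)n1-c1cccc(C(C)(C)C)c1` gives 460 nM in this assay, the lowest of the three numbers, and its steps to the other two both lie beyond the scatter, so it is the strongest inhibitor of this set.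

Compound 4 `CCOc1cccc(-n2c(C)cc(C(=O)O)c2C)c1` has not yet been measured. It differs from compound 3 by ethoxy in place of tert-butyl on an aromatic carbon. Among the measured compounds shown here, two measured steps bear on this change, since both end at compound 3 through the arrival of the tert-butyl group: a 3.3-fold lower number from compound 1 to compound 3 (0.51 log units; beyond the scatter) and a 3.3-fold lower number from compound 2 to compound 3 (0.51 log units; beyond the scatter). For the measured compounds named here, no measured step involves an ethoxy group. With the tert-butyl group now leaving, part of that gain is expected to reverse, so a modest rise in the number is expected. Compound 4 is expected to give 1100 nM in this assay, with a range from 400 nM to 3000 nM. This corresponds to an expected step of a 2.4-fold higher number from compound 3 to compound 4 (0.38 log units; beyond the scatter).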

Compound 4, half-maximal inhibitory concentration: 640 nM
Estimate against measurement, compound 4: 1.7-fold (0.24 log units) above; the range from low to high includes it.
By their numbers in this assay, from the lowest: compounds 3 and 4 (each within the scatter of the next); then compounds 1 and 2 (each within the scatter of the next).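

At this carbon of the shared core, in this assay, ethoxy can take the place of tert-butyl with a 1.4-fold higher number from compound 3 to compound 4 (0.14 log units; within the scatter), so a carbon-only group is not required to keep this level of inhibition. Ethoxy also keeps a gain over both other groups, with a 2.3-fold lower number from compound 2 to compound 4 (0.37 log units; beyond the scatter) and a 2.3-fold lower number from compound 1 to compound 4 (0.37 log units; beyond the scatter), which places ethoxy and tert-butyl together, apart from trifluoromethyl and methyl, among these four compounds. Nothing available here explains why ethoxy and tert-butyl read alike.

Going by these compounds, whether a longer chain such as propoxy, a ring such as cyclopropyl, or an amine at this carbon would stay at the same level remains open. The compounds shown also leave open how ethoxy would read on another carbon of this ring.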